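The compounds below may be only part of what the source reports. "The series", "measured", "known", "first", "only" and "open" are said of these compounds alone.

Measured compounds:
Compound 1, `Cc1c(OCCCCOc2ccccc2C(=O)O)ccc(C(=O)CC2CCCC2)c1O`, gives 98.8%.
Compound 2, `Cc1c(OCCCCOc2ccc(C(=O)O)c(Cl)c2)ccc(C(=O)CC2CCCC2)c1O`, gives 80.8%.
Compound 3, `Cc1c(OCCCCOc2ccc(C(=O)O)c(Cl)c2)ccc(C(=O)CC(C)C)c1O`, gives 80.5%.

All three values come from an assay on HEK293 cells for positive allosteric modulation of metabotropic glutamate receptor 2 (Rattus norvegicus), read by thallium flux, with a stated time of 2.5 min; on this read-out higher numbers stand for larger maximal responses and lower numbers for smaller maximal responses. Compound 1 and compound 2 share one core and differ in a single place: 2-carboxyphenyl in place of 4-carboxy-3-chlorophenyl on an oxygen on a saturated carbon. That change produced a number 18 percentage points higher from compound 2 to compound 1 (beyond the scatter). Compound 2 and compound 3 differ in the core itself: isopropyl in place of cyclopentyl on a saturated chain carbon bound to a carbonyl carbon. Here the outcome was a number 0.3 percentage points lower from compound 2 to compound 3 (within the scatter), so on this read-out the two cores cannot be told apart.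

Compound 4, `Cc1c(OCCCCOc2ccccc2C(=O)O)ccc(C(=O)CC(C)C)c1O`, has not yet been measured in this assay. Set against compound 3 it carries 2-carboxyphenyl in place of 4-carboxy-3-chlorophenyl on an oxygen on a saturated carbon. Among the measured compounds shown here, this is the same change, at the same place, as the one that leads from compound 2 to compound 1, only made on the core of compound 3 instead of the core of compound 2. For the measured compounds named here, that earlier pair is the only measured example of this change, so any expectation rests on one step alone. Because a number 0.3 percentage points lower from compound 2 to compound 3 (within the scatter) shows that the core swap scarcely moved the largest response, the step to compound 4 is expected to resemble the earlier one, with compound 4 expected to show a number 16.5 percentage points higher from compound 3 to compound 4 (beyond the scatter). On that basis compound 4 is estimated at about 97%, with a likely range from 88% to 106%.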

Compound 4, largest response reached (reported as percent of maximum), in percent of the reference or control that the assay uses: 92.4%
Compound 4: middle estimate off by 4.6 percentage points, on the high side; the measured number falls inside the stated range.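

On the core of compound 3, 2-carboxyphenyl in place of 4-carboxy-3-chlorophenyl gave a number 11.9 percentage points higher from compound 3 to compound 4 (beyond the scatter) in this assay, so the rise seen on the first core appeared on the second as well, and the two steps agree: the same change on two cores in this assay, a number 18 percentage points higher (beyond the scatter) from compound 2 to compound 1 and a number 11.9 percentage points higher (beyond the scatter) from compound 3 to compound 4, 6.1 percentage points apart, within the scatter of two such steps. Read the other way, isopropyl in place of cyclopentyl gave a number 6.4 percentage points lower from compound 1 to compound 4 (within the scatter), and this swap made no clear difference with either carboxyphenyl group in place: the same change on two cores in this assay, a number 0.3 percentage points lower (within the scatter) from compound 2 to compound 3 and a number 6.4 percentage points lower (within the scatter) from compound 1 to compound 4, 6.1 percentage points apart, within the scatter of two such steps. This shows that the change carried over between two cores that differ only in isopropyl versus cyclopentyl, but it does not show that it would carry over to a core that differs more, and because 4-carboxy-3-chlorophenyl and 2-carboxyphenyl differ in more than the chlorine, it cannot tell which part of the swap matters.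

The compounds shown leave open how a 4-carboxyphenyl group without the chlorine would behave, a comparison that could help separate the two parts of the swap. They also leave open whether the step would hold with a phenyl group in place of the isopropyl or cyclopentyl, or with a longer chain linking the two oxygens.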